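The source may hold more compounds than are shown below. What is called first, only, known or untested is meant among the compounds shown, and "the series" means these compounds.

Working notes on the series. The shared core of compound 1 `CN(C)CC[C@H](CSc1ccccc1)Nc1ccc(S(=O)(=O)NC(=O)c2ccc(N3CCN(Cc4ccccc4-c4ccc(Cl)cc4)CC3)cc2)cc1OC(F)(F)F` carries a trifluoromethoxy group; compound 2 `CN(C)CC[C@H](CSc1ccccc1)Nc1ccc(S(=O)(=O)NC(=O)c2ccc(N3CCN(Cc4ccccc4-c4ccc(Cl)cc4)CC3)cc2)cc1S(C)(=O)=O` and compound 3 `CN(C)CC[C@H](CSc1ccccc1)Nc1ccc(S(=O)(=O)NC(=O)c2ccc(N3CCN(Cc4ccccc4-c4ccc(Cl)cc4)CC3)cc2)cc1C(=O)C(F)(F)F` differ from it at the same place. In an ADME assay on the whole organism (plasma, strain Sprague-Dawley) for pharmacokinetics, with Rattus norvegicus as the target, at a dose of 5 mg/kg by the oral route (a lower number here means less compound in the circulation, a higher number more compound in the circulation at the dose given), compound 3 gives 1080 ng.h/mL. For compound 1 the entry in this assay reads "not determined" (no result reported), and for compound 2 it reads "not determined" (no result reported); compound 1 therefore has no number of its own to stand on, and only compound 3 supplies a measured point in the series.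

Compound 4 `CN(C)CC[C@H](CSc1ccccc1)Nc1ccc(S(=O)(=O)NC(=O)c2ccc(N3CCN(Cc4ccccc4-c4ccc(Cl)cc4)CC3)cc2)cc1C#N` is the next member and has not yet been measured. The change from compound 1 to compound 4 is cyano in place of trifluoromethoxy on an aromatic carbon. For the measured compounds named here, no measured pair shows the effect of this change, so the expected step in this assay is taken as none beyond the scatter, in either direction, with the single number from compound 3 as the only anchor. On that basis compound 4 is expected to give about 900 ng.h/mL in this assay, within a range from 250 ng.h/mL to 3000 ng.h/mL.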

Compound 4, area under the concentration-time curve: 1740 ng.h/mL
The estimate for compound 4 lay 1.9-fold (0.29 log units) below the measured number; low and high end bracket the measured number.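

In this assay, this position now has its first readable step, a 1.6-fold higher number from compound 3 to compound 4 (0.21 log units; within the scatter), with cyano in place of (trifluoromethyl)carbonyl on an aromatic carbon. The two groups therefore cannot be told apart in this assay, and compound 4 adds a second measured point showing that the shared core carries a nitrile here with a reading of the same order as compound 3. Nothing available explains the reading for either group.

The steps to compound 4 from compound 1 and compound 2 cannot be read, so the trifluoromethoxy and methylsulfonyl groups remain unplaced against cyano. Also open, on these data alone, is whether an amine, a carboxylic acid or a plain hydrogen on this aromatic carbon would stay within the scatter of these two values or move clearly beyond it.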